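Thiophen-3-yl for 2-chlorophenyl: the next step from compound 1

The source may report more compounds than this note shows. Statements on the series, on what has been measured and on what is new or still open speak of the compounds shown alone.

Compound 1 `OC(c1ccc(Cl)cc1)(c1cccnc1)c1ccccc1Cl` sits highest of the two numbers in hand in an ADME assay on L6 cells (Rattus norvegicus) for cytotoxicity, read by resazurin assay, with a stated time of 72 h (on this read-out lower numbers stand for stronger inhibition and higher numbers for weaker inhibition), where compound 1 gives 61300 nM. Compound 3 `OC(c1ccc(Cl)cc1)(c1cccnc1)c1ccccc1C(F)(F)F`, with 59300 nM, lies a 1.0-fold lower number from compound 1 to compound 3 (0.01 log units; within the scatter). Compound 2 `OC(c1ccc(Cl)cc1)(c1cnccn1)c1ccccc1Cl` reaches only a limit of this assay, > 100000 nM, so that the limit of > 100000 nM in this assay, at which 1 of the 3 values shown sits, holds. Its step is an at least 1.6-fold higher number from compound 1 to compound 2 (0.21 log units; that floor lies within the scatter). Compound 4 `OC(c1ccc(Cl)cc1)(c1cccnc1)c1ccsc1` differs from compound 1 by thiophen-3-yl in place of 2-chlorophenyl on a saturated chain carbon bound to two aromatic carbons and an oxygen on a saturated carbon. Neither measured step touches this position; both stay within the scatter, so no shift beyond the scatter is expected here either. Compound 4 is therefore estimated at 70000 nM in this assay, within 30000 nM to 160000 nM, an expected step of a 1.1-fold higher number from compound 1 to compound 4 (0.06 log units; within the scatter).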

Compound 4, half-maximal inhibitory concentration: > 100000 nM
Compound 4: a limit, no number (the forecaster's own chance of this, stated with the estimate: 35%); middle value at least 1.4-fold (0.15 log units) from the limit.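

Thiophen-3-yl in place of 2-chlorophenyl is the first change at this position, and in this assay compound 4 reaches only a limit, > 100000 nM. The step is an at least 1.6-fold higher number from compound 1 to compound 4 (0.21 log units; that floor lies within the scatter), so no lower number appears with this ring, but a shift beyond the scatter is neither shown nor excluded. The exact size of the step stays unreadable, and this result adds to the values capped by the assay: the limit of > 100000 nM in this assay, at which 2 of the 4 values shown sit.

Still open, on these data alone, is how a phenyl without chloro or a ring bearing an amine at this position would read in this assay.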